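The compounds below may be only part of what the source reports. "The series", "measured", "known", "first", "only" and "open" are said of these compounds alone.

Series notes. Compound 1 `CCCn1c(=O)c2nc(C3CCCC(N)C3)[nH]c2n(CCC)c1=O` and compound 2 `CCCn1c(=O)c2nc(NC3CCCC3)[nH]c2n(CCC)c1=O` share a core and differ only at one aromatic carbon. Among the measured compounds shown here, in a functional assay for antagonist activity at adenosine receptor A1 (Homo sapiens) (on this read-out lower numbers stand for stronger inhibition and higher numbers for weaker inhibition), compound 1 gives 50 nM, and compound 2 gives 8 nM; the step of a 6.3-fold lower number from compound 1 to compound 2 (0.80 log units; beyond the scatter) is the only measured step in hand. Compound 2 therefore stands at the lowest of the two numbers in this assay, with compound 1 as its nearest neighbour.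

Compound 3 `CCCn1c(=O)c2nc(CC3CCCC3)[nH]c2n(CCC)c1=O` is the next member; from compound 2 it differs by cyclopentylmethyl in place of cyclopentylamino on an aromatic carbon. For the measured compounds named here, no measured step bears directly on this exchange: the step of a 6.3-fold lower number from compound 1 to compound 2 (0.80 log units; beyond the scatter) changed the ring and the point of attachment together, whereas here the ring is kept and only the attachment changes. With nothing in the numbers pointing to a direction, a small step is expected, slightly towards a higher number, a 3.1-fold higher number from compound 2 to compound 3 (0.49 log units; beyond the scatter). Compound 3 is estimated at 25 nM in this assay, within 5 nM to 120 nM.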

Compound 3, inhibition constant: 69 nM
For compound 3 the middle estimate is 2.8-fold (0.44 log units) below the measured one; the measured number falls inside the stated range.
By their numbers in this assay, from the lowest: compound 2; then compounds 1 and 3 (each within the scatter of the next).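

With the cyclopentyl ring kept, the change of attachment is seen on its own: in this assay the exchange of cyclopentylamino for cyclopentylmethyl gives an 8.6-fold higher number from compound 2 to compound 3 (0.94 log units; beyond the scatter) and so separates a contribution that the earlier step had mixed with a change of ring. The numbers do not separate cyclopentylmethyl from 3-aminocyclohexyl, with a 1.4-fold higher number from compound 1 to compound 3 (0.14 log units; within the scatter) on the same read-out, and among the three groups shown only cyclopentylamino stands apart. No evidence is available to explain the step from cyclopentylamino to cyclopentylmethyl.

The compounds shown leave open whether any other attaching atom or direct ring attachment keeps the number of compound 2, as cyclopentyloxy or plain cyclopentyl would show. Cyclohexylamino would show whether the amino attachment tolerates the larger ring.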